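This account rests on a few compounds, and the source may have more. Where it says the series, first, only, none or still open, it means among the compounds named here.

Compound 1 `Fc1cccc(-c2nc(Nc3ccccc3)c3cc(F)ccc3n2)c1` and compound 2 `Fc1cccc(Nc2nc(-c3cccc(F)c3)nc3ccc(F)cc23)c1` share one core. In a functional assay on HT29-AK cells (Homo sapiens) for cytotoxicity, read by MTT assay, with a stated time of 48 h (a higher number here means a weaker inhibitor, a lower number a stronger inhibitor), compound 1 gives 48300 nM. For compound 2 the assay reports only a limit, > 50000 nM. Among the compounds with values here, the sole measured step, an at least 1.0-fold higher number from compound 1 to compound 2 (0.01 log units; that floor lies within the scatter), cannot be sized because it ends at the limit of > 50000 nM in this assay, at which 1 of the 2 values shown sits. Compound 3 `Oc1ccccc1Nc1nc(-c2cccc(F)c2)nc2ccc(F)cc12` differs from compound 2 by 2-hydroxyphenyl in place of 3-fluorophenyl on a nitrogen on an aromatic ring. Within the data shown here, no measured step bears on this change, so no shift beyond the scatter is expected. Compound 3 is therefore estimated at 50000 nM, within 15000 nM to 120000 nM. That estimate means an expected step of a number no higher from compound 2 to compound 3 (the limit leaves the size open).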

Compound 3, half-maximal inhibitory concentration: > 50000 nM
Compound 3: no number, only a limit (the forecaster's own chance of this, stated with the estimate: 60%); the middle value sits exactly at the limit.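

In this assay, compound 3, which carries 2-hydroxyphenyl and so adds a hydrogen-bond donor on the nitrogen, gives only a limit, > 50000 nM. Within the data shown here, the one readable comparison is an at least 1.0-fold higher number from compound 1 to compound 3 (0.01 log units; that floor lies within the scatter), so adding a hydroxy gives no sign of a stronger inhibitor. The step from compound 2 to compound 3 cannot be read because both values are limits: the limit of > 50000 nM in this assay, at which 2 of the 3 values shown sit.

On these data alone, it remains open how far compound 2 and compound 3 lie past that limit. As far as these compounds go, it also remains open whether an amine or a carboxylic acid in place of the hydroxy would give a readable number.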